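Chloro for Amino on a Urea: Cytotoxicity Outlook

A few compounds are considered here, and "the series" means these few. Any claim that something is new, unique, unknown or untested is made for them only; others in the source may bear on it.

Measured compounds:
- compound 1, `Cc1cc(NC(=O)Nc2ccc(N)cc2)c2ccccc2n1`: in an ADME assay on BJ cells (Homo sapiens) for cytotoxicity, with a stated time of 72 h (a higher number here means that more compound is needed for the effect, a lower number that less compound is needed), compound 1 gives only a limit, > 25000 nM
- compound 2, `Cc1cc(NC(=O)Nc2ccc(F)c(F)c2)c2ccccc2n1`: in this assay compound 2 gives only a limit, > 25000 nM
- compound 3, `Cc1cc(NC(=O)Nc2ccc3[nH]cnc3c2)c2ccccc2n1`: in this assay compound 3 gives only a limit, > 25000 nM

All three measured compounds share the same core and differ only in the aromatic ring on the far side of the urea. None of them reaches a measurable number in this assay; each sits at the limit of > 25000 nM in this assay, at which 3 of the 3 values shown sit. Compound 1 therefore stands at the limit of the assay, and the two other values give no ordering among the three, since a limit is not a number.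

The unmeasured compound 4, `Cc1cc(NC(=O)Nc2ccc(Cl)cc2)c2ccccc2n1`, differs from compound 1 by chloro in place of amino on an aromatic carbon. Among the measured compounds shown here, no step between measured compounds is available for this change. With every measured value at the limit, the step that the limit leaves unreadable from compound 1 to compound 4 is expected to be none beyond the scatter, most likely ending again at the limit.

Compound 4 is thus estimated at 30000 nM, with a range from 10000 nM to 100000 nM.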

Compound 4, half-maximal effective concentration: > 25000 nM
Compound 4 ended at the assay's limit; the forecaster's own chance of this, stated with the estimate: 85%; the middle value lies beyond the limit too.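

No step from compound 1 to compound 4 can be read, since both compounds give a limit rather than a number: the limit of > 25000 nM in this assay, at which 4 of the 4 values shown sit.

The compounds shown leave open whether any group in place of amino would give a measurable value in this assay, and how these four compounds rank against one another.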